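The source may hold more compounds than are shown below. What is called first, only, known or untested is meant among the compounds shown, and "the series" means these compounds.

Working notes on the series. Compound 2 `NCCCCCCOc1ccc2c(=O)c(-c3ccc(O)cc3)coc2c1` gives 100 nM in an assay (Cricetulus griseus) for inhibition of aldehyde dehydrogenase, mitochondrial (Homo sapiens); on this read-out lower numbers stand for stronger inhibition and higher numbers for weaker inhibition. Compound 3 `O=C(O)CCCCOc1ccc2c(=O)c(-c3ccc(O)cc3)coc2c1` gives 100 nM in this assay, so the step of no change at the digits printed from compound 2 to compound 3 (within the scatter) is flat. Compound 1 `O=C(O)COc1ccc(-c2coc3cc(OCC(=O)O)ccc3c2=O)cc1` is a separate case: in this assay compound 1 returns a limit rather than a number, >> 9000 nM. That limit is the single one among the three values, (the limit of >> 9000 nM in this assay, at which 1 of the 3 values shown sits). Among the measured compounds shown here, no step connects compound 1 to either of the others, so its value is recorded and left there.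

Where compound 3 stands: level with compound 2 at the digits shown, compound 2 being its nearest measured neighbour, with the remaining value a limit.

Compound 4 `CCOC(=O)CCCCOc1ccc2c(=O)c(-c3ccc(O)cc3)coc2c1` differs from compound 3 by ethyl in place of hydrogen on an oxygen next to a carbonyl group. For the measured compounds named here, none of the measured steps touches this oxygen. Going by the values given here, the one measured step, no change at the digits printed from compound 2 to compound 3 (within the scatter), put carboxy in place of 2-aminoethyl at the far end of the same chain without moving the read-out, which is the only hint that the chain end tolerates variation, and it says nothing directly about capping the acid as an ester. On that thin basis the step of a 1.2-fold higher number from compound 3 to compound 4 (0.08 log units; within the scatter) is expected to stay within the scatter. Compound 4 is therefore estimated at 120 nM in this assay, with a range from 30 nM to 500 nM.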

Compound 4, half-maximal inhibitory concentration: 240 nM
For compound 4 the middle estimate is 2.0-fold (0.30 log units) below the measured one; low and high end bracket the measured number.
By their numbers in this assay, from the lowest: compounds 2 and 3 (each within the scatter of the next); then compound 4. At a limit, above all of these: compound 1.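

Ethyl in place of hydrogen on an oxygen next to a carbonyl group gives a 2.4-fold higher number from compound 3 to compound 4 (0.38 log units; beyond the scatter) in this assay, so this oxygen responds to substitution, though only modestly. The same holds against the amine-ended compound, with ethoxycarbonyl in place of 2-aminoethyl giving a 2.4-fold higher number from compound 2 to compound 4 (0.38 log units; beyond the scatter) in this assay, whereas carboxy in that place gave no change at the digits printed from compound 2 to compound 3 (within the scatter); the flat reading of the chain end therefore covers the amine and the free acid but does not extend to the ethyl ester. Nothing measured here accounts for the shift, which stands as an observation without an explanation.

A methyl ester, a tert-butyl ester or a primary amide on the same chain would show whether the change in read-out follows the size of the group on this oxygen or comes with any capping of the carboxy group. Among the compounds shown here, it also remains open whether the modest step seen with ethyl would hold on a shorter or longer chain, since every comparison at this oxygen so far rests on the single chain of compound 3.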